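From Compound 3 to Compound 4: Keeping a Hydroxy

The source may hold more compounds than are shown below. What is called first, only, known or untested is meant among the compounds shown, and "the series" means these compounds.

Compound 1 `COc1ccc(-c2nc3cccc(-c4cc(OC)c(OC)c(OC)c4)c3o2)cc1OC`: > 25000 nM (a limit)
Compound 2 `COc1cc(-c2cccc3nc(-c4cccc(C)c4)oc23)cc(OC)c1OC`: > 25000 nM (a limit)
Compound 3 `COc1cc(-c2cccc3nc(-c4cccc(O)c4)oc23)cc(OC)c1OC`: 1900 nM

In a functional assay on NCI-H460 cells (Homo sapiens) for antiproliferative activity, read by MTT assay, with a stated time of 48 h (on this read-out higher numbers stand for weaker inhibition and lower numbers for stronger inhibition), compound 3 alone gives a number, 1900 nM. Compound 1 and compound 2 give only limits.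

Compound 4 `COc1cc(-c2nc3cccc(-c4cc(OC)c(OC)c(OC)c4)c3o2)ccc1O` carries 4-hydroxy-3-methoxyphenyl in place of 3-hydroxyphenyl on an aromatic carbon.

Among the measured compounds shown here, two measured steps bear on this change: an at least 13-fold lower number from compound 1 to compound 3 (1.11 log units; beyond the scatter), and an at least 13-fold lower number from compound 2 to compound 3 (1.11 log units; beyond the scatter). For the measured compounds named here, both are large and end at the one compound with a hydroxy. The entering group keeps a hydroxy but also has a methoxy, so only a modest move towards weaker inhibition is expected. The expected step is a 2.1-fold higher number from compound 3 to compound 4 (0.32 log units; beyond the scatter). For compound 4 the estimated value is 4000 nM, with an expected range from 800 nM to 20000 nM.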

Compound 4, half-maximal inhibitory concentration: 2000 nM
Estimate against measurement, compound 4: 2.0-fold (0.30 log units) above; the range from low to high includes it.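

In this assay there is a 1.1-fold higher number from compound 3 to compound 4 (0.02 log units; within the scatter) and so 4-hydroxy-3-methoxyphenyl and 3-hydroxyphenyl cannot be told apart at this position. Hydrogen in place of methyl on a single oxygen of this ring gives an at least 12-fold lower number from compound 1 to compound 4 (1.09 log units; beyond the scatter) and 4-hydroxy-3-methoxyphenyl in place of 3-methylphenyl gives an at least 12-fold lower number from compound 2 to compound 4 (1.09 log units; beyond the scatter) on the same read-out, so in all the compounds shown a number appears only with a hydroxy on this ring. Both large steps start from a limit and not from a number: the limit of > 25000 nM in this assay, at which 2 of the 4 values shown sit. From the compounds shown here alone, whether an amine or a carboxylic acid in place of that hydroxy would give a comparable number stays open.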